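The source may report more compounds than this note shows. Statements on the series, on what has been measured and on what is new or still open speak of the compounds shown alone.

Measured compounds:
- Compound 1 `Cc1ccc(C(=O)Nc2cccc(CN3CCN(C)CC3)c2)cc1-c1ccc2cn[nH]c2c1`: in an assay on isolated protein for inhibition of Discoidin domain-containing receptor 2 (Homo sapiens), read by ELISA, with a stated time of 60 min (on this read-out higher numbers stand for weaker inhibition and lower numbers for stronger inhibition), compound 1 gives 75.9 nM
- Compound 2 `Cc1ccc(C(=O)Nc2cc(CN3CCN(C)CC3)cc(C(F)(F)F)c2)cc1-c1ccc2cn[nH]c2c1`: compound 2 gives 4.7 nM
- Compound 3 `Cc1ccc(C(=O)Nc2cccc(C(F)(F)F)c2)cc1-c1ccc2c(-c3ccc(N4CCN(C)CC4)cc3)n[nH]c2c1`: compound 3 gives 8.8 nM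

On these three numbers compound 3 stands second highest. Its nearest neighbour is compound 2, and the two values lie within the scatter of each other; its furthest is compound 1, whose number is clearly higher, beyond the scatter. Compound 4 `Cc1ccc(C(=O)Nc2cccc(C(F)(F)F)c2)cc1-c1ccc2c(-c3ccc(CN4CCN(C)CC4)cc3)n[nH]c2c1` is the unmeasured partner of compound 3. Going by the values given here, the single change is (4-methylpiperazin-1-yl)methyl in place of 4-methylpiperazin-1-yl on an aromatic carbon: a one-carbon link is inserted between the ring and the 4-methylpiperazine.

Among the compounds with values here, the only step measured so far, a 16-fold lower number from compound 1 to compound 2 (1.21 log units; beyond the scatter), concerns a trifluoromethyl in place of hydrogen on the anilide ring and does not touch the piperazine or its attachment, so it offers no direct guide. Within the data shown here, no measured pair isolates the effect of a methylene spacer here. With nothing in the data pointing either way, the expectation for compound 4 is a step of a 1.0-fold higher number from compound 3 to compound 4 (0.01 log units; within the scatter), no change beyond the scatter, so compound 4 is estimated at 9 nM, within 3 nM to 27 nM.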

Compound 4, half-maximal inhibitory concentration: 6.2 nM
Beside the measured number, compound 4's estimate is 1.5-fold (0.16 log units) above it, and the stated range covers the measured number.
By their numbers in this assay, from the lowest: compounds 2, 4 and 3 (each within the scatter of the next); then compound 1.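

In this assay the one-carbon link inserted between the aromatic ring and the 4-methylpiperazine gives a 1.4-fold lower number from compound 3 to compound 4 (0.15 log units; within the scatter) and so leaves the two compounds indistinguishable on this read-out. Going by these compounds alone, this is the first measured pair to isolate that link, since the earlier step concerned trifluoromethyl in place of hydrogen elsewhere in the molecule. At this place, para to a large group, either attachment of the 4-methylpiperazine fits with a low-nanomolar value, and no measurement at hand explains why the link makes so little difference.

The compounds shown leave open whether a longer chain to the 4-methylpiperazine would keep this level of inhibition. They also leave open what a morpholine or a carboxylic acid would do in place of the 4-methylpiperazine at this position.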